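The source may report more compounds than this note shows. Statements on the series, on what has been measured and on what is new or still open speak of the compounds shown alone.

Compound 1 `O=C1C=CC(OCC(F)(F)F)N1c1cc(Cl)cc(Cl)c1`: 2430 nM
Compound 2 `CC(C)c1ccc(N2C(=O)C=CC2OCC(F)(F)F)cc1`: 6640 nM
Compound 3 `Cc1ccc(N2C(=O)C=CC2OCC(F)(F)F)cc1`: 15800 nM

In a functional assay on MDA-MB-231 cells (Homo sapiens) for inhibition (a lower number here means a stronger inhibitor, a higher number a weaker inhibitor), compound 3 gives the highest number of the three measured compounds, with compound 2 nearest to it and compound 1 furthest away, both steps lying beyond the scatter. Compound 4 `O=C1C=CC(OCC(F)(F)F)N1c1ccccc1` differs from compound 3 in one place: hydrogen in place of methyl on an aromatic carbon. Among the measured compounds shown here, only one measured step bears on this change, namely a 2.4-fold higher number from compound 2 to compound 3 (0.38 log units; beyond the scatter), where trimming the group on that same aromatic carbon already raised the number. Taking the trimming one stage further, a further modest rise in this assay is expected, although part of it could fall within the scatter. Compound 4 is therefore estimated at 30000 nM, within a range of 12000 nM to 80000 nM, which means an expected 1.9-fold higher number from compound 3 to compound 4 (0.28 log units; within the scatter).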

Compound 4, half-maximal inhibitory concentration: 15300 nM
The estimate for compound 4 lay 2.0-fold (0.29 log units) above the measured number; measured number inside the range.
By their numbers in this assay, from the lowest: compound 1; then compound 2; then compounds 4 and 3 (each within the scatter of the next).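

In this assay, putting hydrogen in place of methyl gives a 1.0-fold lower number from compound 3 to compound 4 (0.01 log units; within the scatter), so at this position the two groups cannot be told apart. Putting hydrogen in place of isopropyl gives a 2.3-fold higher number from compound 2 to compound 4 (0.36 log units; beyond the scatter), so the rise seen on trimming isopropyl to methyl does not continue when the methyl is removed as well. Nothing available gives a reason for this pattern. Open, from the compounds shown here alone, is whether a tert-butyl group, a longer chain, a methoxy group or an amine at this same position would lower the number further or raise it.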